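Swapping Diethylamino for Piperidinyl on a Longer Chain

The source may hold more compounds than are shown below. What is called first, only, known or untested is meant among the compounds shown, and "the series" means these compounds.

Compound 1 `CCN(CC)CCCCOc1ccc(/C=C/C(=O)Nc2ccccc2)cc1OC` and compound 2 `COc1cc(/C=C/C(=O)Nc2ccccc2)ccc1OCCCCN1CCCCC1` share one core and differ in a single place: piperidin-1-yl in place of diethylamino on a saturated chain carbon, four bonds along the chain from an oxygen on an aromatic ring. In a physicochemical assay for lipophilicity, using the shake flask method, measured as octanol-water partition, at pH 7.4 (a higher number here means a more lipophilic compound, a lower number a more polar compound), compound 1 gives 1.59 and compound 2 gives 1.61, so that exchange made a number 0.02 log units higher from compound 1 to compound 2 (within the scatter). Compound 3 `CCN(CC)CCCCCCOc1ccc(/C=C/C(=O)O)cc1OC` has a different core; how it differs from compound 1 is not broken down here. In this assay compound 3 gives 1.29, which lies within the scatter of compound 1 but beyond the scatter from compound 2. Compound 4 `COc1cc(/C=C/C(=O)O)ccc1OCCCCCCN1CCCCC1` is not yet measured and differs from compound 3 by piperidin-1-yl in place of diethylamino on a saturated chain carbon, six bonds along the chain from an oxygen on an aromatic ring. This is the same kind of change as before, though here it sits six bonds along the chain from an oxygen on an aromatic ring rather than four. Because a number 0.02 log units higher from compound 1 to compound 2 (within the scatter) stayed within the scatter, a similar small step is expected here, namely a number 0.04 log units higher from compound 3 to compound 4 (within the scatter). Compound 4 is therefore estimated at 1.33, somewhere between 1 and 1.66.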

Compound 4, partition coefficient: 1.32
Compound 4: middle estimate off by 0.01 log units, on the high side, and the stated range covers the measured number.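

In this assay the exchange of diethylamino for piperidin-1-yl gives a number 0.03 log units higher from compound 3 to compound 4 (within the scatter) and, on the core of compound 1, a number 0.02 log units higher from compound 1 to compound 2 (within the scatter) and both steps lie within the scatter, so across these two cores the exchange looks equally small. That rests on just two pairs, which differ in core and also in place, six bonds along the chain against four, and the data cannot separate those two differences or show that the result holds on any other core. Nothing measured here offers an explanation for the result.

Going by these compounds, whether the step stays this small with morpholin-4-yl or pyrrolidin-1-yl in place of piperidin-1-yl remains open. So does its size on a longer chain.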